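Sulfonyl aryl variation: from compound 2 to compound 3

A few compounds are considered here, and "the series" means these few. Any claim that something is new, unique, unknown or untested is made for them only; others in the source may bear on it.

Measured so far:
compound 1, `COc1cc(N)c(Cl)cc1C(=O)CCC1CCN(CCNS(=O)(=O)c2cc(Br)ccc2Br)CC1`, gives 16.3 nM in an assay on brain for displacement of a labelled ligand from 5-hydroxytryptamine receptor 4 (Cavia porcellus), with a stated time of 30 min, in the presence of a further agent that is not named here; a higher number here means a weaker inhibitor, a lower number a stronger inhibitor
compound 2, `COc1cc(N)c(Cl)cc1C(=O)CCC1CCN(CCNS(=O)(=O)c2ccc(C)cc2)CC1`, gives 18 nM in this assay

For the measured compounds named here, compound 2 has the higher of the two numbers measured so far, with compound 1 as its only neighbour; the step of a 1.1-fold higher number from compound 1 to compound 2 (0.04 log units; within the scatter), so on these numbers the two compounds cannot be told apart. Compound 3, `COc1ccc(S(=O)(=O)NCCN2CCC(CCC(=O)c3cc(Cl)c(N)cc3OC)CC2)c(OC)c1`, is still to be measured in this assay. Its change from compound 2: 2,4-dimethoxyphenyl in place of 4-methylphenyl on a sulfonyl sulfur. Going by the values given here, only one measured step touches the aryl group on the sulfonyl sulfur, namely a 1.1-fold higher number from compound 1 to compound 2 (0.04 log units; within the scatter), and it stayed within the scatter even though the two aryl groups involved share no substituent. Among the compounds with values here, no measured compound carries a methoxy group on this aryl ring, so nothing here speaks to methoxy at that place. For compound 3 the expected step is a 1.1-fold higher number from compound 2 to compound 3 (0.05 log units; within the scatter), within the scatter. For compound 3 the estimate is 20 nM, with a range from 8 nM to 50 nM.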

Compound 3, inhibition constant: 18.7 nM
Compound 3: middle estimate off by 1.1-fold (0.03 log units), on the high side; low and high end bracket the measured number.
By their numbers in this assay, from the lowest: compounds 1, 2 and 3 (each within the scatter of the next).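

In this assay the aryl group on the sulfonyl sulfur now has a third member, the first with methoxy groups: 2,4-dimethoxyphenyl in place of 4-methylphenyl gives (a 1.0-fold higher number from compound 2 to compound 3 (0.02 log units; within the scatter)), and 2,4-dimethoxyphenyl in place of 2,5-dibromophenyl gives (a 1.1-fold higher number from compound 1 to compound 3 (0.06 log units; within the scatter)). Both steps lie within the scatter, so 4-methylphenyl, 2,5-dibromophenyl and 2,4-dimethoxyphenyl cannot be told apart at this position on these numbers, even though the entering group has 10 heavy atoms and 2 hydrogen-bond acceptors where 4-methylphenyl has 7 and 0. No supporting data are available to account for this result.

From the compounds shown here alone, all three compounds keep a substituted phenyl ring on the sulfonyl sulfur, so it remains open whether a pyridine ring or a simple methyl group at that place would give a number in the same range in this assay. Also open, going by these compounds, is whether an amine or a carboxylic acid on the aryl ring, or a longer chain between the aryl ring and the sulfonyl sulfur, would move the number beyond the scatter.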